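The compounds below may be only part of what the source reports. "The series", "measured", "known", "first", "only" and "open" are said of these compounds alone.

Measured compounds in the series:

Compound 1 `COc1ccc2c(c1)/C(=N/NC(=S)Nc1ccccc1)C(=O)N2`. In an ADME assay on RD cells (Homo sapiens) for cytotoxicity (a higher number here means that more compound is tolerated, a lower number that less compound is tolerated), compound 1 gives > 25000 nM, a limit of the assay and not a number.
Compound 2 `CNC(=S)N/N=C1\C(=O)Nc2ccccc21`. In this assay compound 2 gives > 25000 nM, again a limit of the assay.
Compound 3 `O=C1Nc2ccccc2/C1=N/NC(=S)N1CCCC1`. In this assay compound 3 gives > 25000 nM, also a limit.

Compound 2 therefore stands at the limit of this assay, and so do the two other measured values; this is the whole of the evidence (the limit of > 25000 nM in this assay, at which 3 of the 3 values shown sit). Among the measured compounds shown here, the only single-point step among measured compounds is a step that the two limits leave unreadable from compound 2 to compound 3, which the two limits leave unreadable in size.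

The next compound is compound 4 `O=C1Nc2ccccc2/C1=N/NC(=S)Nc1ccc(Br)cc1`. It differs from compound 2 by 4-bromophenyl in place of methyl on an amide-type nitrogen. For the measured compounds named here, no measured step bears directly on this change; the closest analogy is the unreadable a step that the two limits leave unreadable from compound 2 to compound 3, and compound 1, which carries a phenyl on that nitrogen, sits at the same limit as compound 2. Nothing seen so far points to a readable change in this assay in either direction.

Compound 4 is therefore expected to sit at the limit as well, with 40000 nM estimated, in a range from 20000 nM to 100000 nM. The step from compound 2 to compound 4 is expected to be a step that the limit leaves unreadable from compound 2 to compound 4, not beyond the scatter.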

Compound 4, half-maximal cytotoxic concentration: > 25000 nM
Compound 4: only a limit was reported; the forecaster's own chance of this, stated with the estimate: 85%; the middle value lies beyond the limit too.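

In this assay compound 4 gives > 25000 nM, a limit of the assay and not a number. The change from compound 2 to compound 4 therefore yields no readable step. The compounds shown leave open at what concentration any of them becomes cytotoxic, and whether the groups that differ among them change this read-out at all: the limit of > 25000 nM in this assay, at which 4 of the 4 values shown sit.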